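Chalcone amide series: tolerability notes ahead of compound 4

The source may hold more compounds than are shown below. What is called first, only, known or untested is meant among the compounds shown, and "the series" means these compounds.

The series shares one core carrying a cinnamoyl aryl ketone; the compounds differ only in the aryl group on that carbonyl carbon. Compound 1 `COC(=O)c1cc(-c2cccc(NC(=O)c3ccc(/C=C/C(=O)c4cccs4)cc3)c2)on1` carries a thienyl ketone; in an ADME assay on Vero cells (Chlorocebus sabaeus) for cytotoxicity, read by MTT assay, with a stated time of 72 h (a lower number here means that less compound is tolerated, a higher number that more compound is tolerated), compound 1 has no result reported, "not determined" (no result reported). Compound 2 `COC(=O)c1cc(-c2cccc(NC(=O)c3ccc(/C=C/C(=O)c4cccc(C(F)(F)F)c4)cc3)c2)on1` is the reference for the step considered here. In this assay compound 2 reaches only a limit, > 20 ug/mL. Compound 3 `COC(=O)c1cc(-c2cccc(NC(=O)c3ccc(/C=C/C(=O)c4ccc(Cl)cc4Cl)cc3)c2)on1` likewise gives only a limit in this assay, > 40 ug/mL. The step from compound 2 to compound 3 is therefore not readable, a step that the two limits leave unreadable from compound 2 to compound 3: both ends are limits, one sitting at the limit of > 20 ug/mL in this assay, at which 1 of the 3 values shown sits, and the other at the limit of > 40 ug/mL in this assay, at which 1 of the 3 values shown sits, and no direction or size can be taken from them. Compound 2 thus stands on a single limit, with one further limit beside it and one entry without a number.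

Compound 4 `COC(=O)c1cc(-c2cccc(NC(=O)c3ccc(/C=C/C(=O)c4ccc(CC(C)C)cc4)cc3)c2)on1` differs from compound 2 as follows: 4-isobutylphenyl in place of 3-(trifluoromethyl)phenyl on a carbonyl carbon. Among the compounds with values here, no measured step bears on this change with a readable size. Within the data shown here, the only evidence is that neither compound 2 nor compound 3 showed toxicity within the tested range, so for compound 4 the expectation is a value close to or beyond those limits. The expected step is a step that the limit leaves unreadable from compound 2 to compound 4. Compound 4 is estimated at 40 ug/mL, with a range from 20 ug/mL to 80 ug/mL, and most likely the assay again returns only a limit.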

Compound 4, half-maximal cytotoxic concentration: > 10 ug/mL
Compound 4: a limit, no number (the forecaster's own chance of this, stated with the estimate: 70%); the middle value lies beyond the limit too.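

In this assay compound 4 also gives only a limit, so neither the step from compound 2 to compound 4 nor the step from compound 3 to compound 4 can be read. Still open, from the compounds shown here alone, is where the half-maximal cytotoxic concentration of compound 2, compound 3 and compound 4 lies, and whether the aryl group on the carbonyl carbon changes it at all.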